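Dithiocarbamate amine change at the thiocarbonyl carbon

A few compounds are considered here, and "the series" means these few. Any claim that something is new, unique, unknown or untested is made for them only; others in the source may bear on it.

Working notes on a set of chromenone dithiocarbamates tested in a functional assay on MCF7 cells (Homo sapiens) for antiproliferative activity, read by MTT assay, with a stated time of 72 h; on this read-out higher numbers stand for weaker inhibition and lower numbers for stronger inhibition. Compound 1 `CCOC(=O)c1cc(=O)c2cc(CSC(=S)N(C)c3ccccc3)ccc2o1` carries a methyl(phenyl)amino group on the thiocarbonyl carbon. In this assay compound 1 returns only a limit of > 25000 nM; this is an assay limit, not a number. As far as these compounds go, compound 1 therefore stands at the limit of > 25000 nM in this assay, at which 1 of the 3 values shown sits, so its true value is unknown beyond that boundary. The two companions give numbers: compound 2 `O=c1cc(CSC(=S)N2CCCC2)oc2ccccc12` in this assay gives 35800 nM, and compound 3 `Cc1ccc2c(=O)c(CSC(=S)N(C(C)C)C(C)C)coc2c1` in this assay gives 6600 nM. Among the measured compounds shown here, their cores differ from that of compound 1, so no single-change step links them, and the numbers are stated only as they are.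

The unmeasured compound 4 `CCOC(=O)c1cc(=O)c2cc(CSC(=S)N3CCOCC3)ccc2o1` keeps the core of compound 1 and differs in one place: morpholin-4-yl in place of methyl(phenyl)amino on a thiocarbonyl carbon. For the measured compounds named here, no measured step of this kind exists in the set. Because compound 1 sits at the limit of > 25000 nM in this assay, at which 1 of the 3 values shown sits, and the remaining values fall near the weak end, the expectation for compound 4 is a weak antiproliferative readout, with a substantial chance that this assay again reports only a limit. The step expected is a step that the limit leaves unreadable from compound 1 to compound 4, not distinguishable from the scatter given that compound 1 is a limit. For compound 4 the estimated value is 30000 nM, with a range from 8000 nM to 100000 nM.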

Compound 4, half-maximal inhibitory concentration: > 25000 nM
Compound 4: a limit, no number (the forecaster's own chance of this, stated with the estimate: 55%); the middle value is on the limit's open side.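

Compound 1 and compound 4 each return only an assay limit, not a number, and no step can be read between them for morpholin-4-yl in place of methyl(phenyl)amino. The compounds shown leave open how far each true value lies beyond the limit, and whether this change on the thiocarbonyl carbon alters antiproliferative activity at all.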